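The source may report more compounds than this note shows. Statements on the series, on what has been measured and on what is new or still open speak of the compounds shown alone.

Measured so far in a functional assay on HepG2 cells (Homo sapiens) for cytotoxicity, read by MTT assay, with a stated time of 72 h; a lower number here means a stronger inhibitor, a higher number a weaker inhibitor:
compound 1 `Cc1cc(=O)n(-c2ccc(Br)cc2F)nc1C(=O)Nc1ccc(Oc2ncnc3[nH]ccc23)c(F)c1` — 32000 nM
compound 2 `Cc1cc(=O)n(-c2ccc(Br)cc2F)nc1C(=O)Nc1ccc(Oc2ncnc3c2ccn3C)cc1` — 33600 nM
compound 3 `Cc1cc(=O)n(-c2ccccc2OC(F)(F)F)nc1C(=O)Nc1ccc(Oc2ncnc3c2ccn3C)c(F)c1` — > 60000 nM

For compound 3 the result is only a limit of this assay, not a number; (the limit of > 60000 nM in this assay, at which 1 of the 3 values shown sits). Compound 1 and compound 2 give numbers that sit close to each other, within the usual scatter.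

Compound 4 `Cc1cc(=O)n(-c2ccc(Br)cc2F)nc1C(=O)Nc1ccc(Oc2ncnc3c2ccn3C)c(F)c1` has not yet been measured. It differs from compound 3 in one place: 4-bromo-2-fluorophenyl in place of 2-(trifluoromethoxy)phenyl on an aromatic nitrogen. Among the compounds with values here, the entering group is the one carried by compound 1 and compound 2. The expected step from compound 3 to compound 4 is an at least 2.0-fold lower number from compound 3 to compound 4 (0.30 log units; that floor lies within the scatter), toward a stronger inhibitor, a number rather than a limit. Compound 4 is expected to give about 30000 nM in this assay, with a range from 14000 nM to 60000 nM. This expectation rests on compound 1 at 32000 nM and on compound 2 at 33600 nM, both with the entering group.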

Compound 4, half-maximal inhibitory concentration: > 60000 nM
Compound 4: only a limit was reported; the forecaster's own chance of this, stated with the estimate: 25%; at least 2.0-fold (0.30 log units) between middle value and limit.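

In this assay compound 4 gives only a limit of the assay, > 60000 nM, so the step between compound 3 and compound 4 cannot be read. Fluoro in place of hydrogen gives an at least 1.7-fold higher number from compound 2 to compound 4 (0.25 log units; that floor lies within the scatter), and methyl in place of hydrogen gives an at least 1.8-fold higher number from compound 1 to compound 4 (0.27 log units; that floor lies within the scatter). Compound 3 and compound 4 both end at the limit, so 4-bromo-2-fluorophenyl on the aromatic nitrogen yields no number here: the limit of > 60000 nM in this assay, at which 2 of the 4 values shown sit.

From the compounds shown here alone, how far compound 4 lies past its limit stays open. Also open, going by these compounds, is whether a carboxylic acid or an amine on the phenyl group at that aromatic nitrogen would give a number.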